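A few compounds are considered here, and "the series" means these few. Any claim that something is new, unique, unknown or untested is made for them only; others in the source may bear on it.

Measured so far:
- compound 1, `Cc1ccc(Nc2ncc3c(n2)N(Cc2ccccc2)C(=O)N(c2cc(NC(=O)c4ccc(C)c(C(F)(F)F)c4)ccc2C)C3)cn1`: > 5000 nM
- compound 2, `CCN1CCN(C(=O)c2ccc(Nc3ncc4c(n3)N(C)C(=O)N(c3cc(NC(=O)c5ccc(CN6CCC(N(C)C)C6)c(C(F)(F)F)c5)ccc3C)C4)cn2)CC1`: 704 nM
- compound 3, `Cc1ccc(NC(=O)c2cccc(C(F)(F)F)c2)cc1N1Cc2cnc(NC3CC3)nc2N(C)C1=O`: 5060 nM

All three were tested in an ADME assay on BaF3 cells (Mus musculus) for inhibition, read by CellTiter-Glo, with a stated time of 72 h; a higher number here means a weaker inhibitor of growth, a lower number a stronger inhibitor of growth. Compound 1 gives > 5000 nM there, and that is a limit of the assay, not a measured number. It sits at the limit of > 5000 nM in this assay, at which 1 of the 3 values shown sits. Among the measured compounds shown here, compound 2 gives 704 nM in this assay, and compound 3 gives 5060 nM; these two carry different substituents from compound 1 in more than one place, so no single step connects them to it, and only the values themselves can be compared.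

Compound 4, `Cc1ccc(Nc2ncc3c(n2)N(C2CCCCC2)C(=O)N(c2cc(NC(=O)c4ccc(C)c(C(F)(F)F)c4)ccc2C)C3)cn1`, has not yet been measured. It differs from compound 1 in one place: cyclohexyl in place of benzyl on an amide-type nitrogen in a ring. A ring of similar size takes the place of the benzyl group on the amide-type nitrogen, while the rest of the molecule stays the same. For the measured compounds named here, with compound 1 already at the limit of this assay, there is no measured step to lean on, and an estimate can only start from where compound 1 stands.

The step from compound 1 to compound 4 is expected to be small, a step that the limit leaves unreadable from compound 1 to compound 4, most likely within the usual scatter. Compound 4 is therefore estimated to give about 6000 nM in this assay, with a likely range from 2000 nM to 20000 nM.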

Compound 4, concentration for 50% growth inhibition: > 5000 nM
Compound 4 gave a limit, no number; the forecaster's own chance of this, stated with the estimate: 55%; the middle value lies beyond the limit too.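

In this assay compound 4 gives > 5000 nM, which is a limit of the assay and not a number. Compound 1 also stands at a limit, so no step between compound 1 and compound 4 can be read: the limit of > 5000 nM in this assay, at which 2 of the 4 values shown sit.

The compounds shown leave open whether benzyl or cyclohexyl on the amide-type nitrogen gives the stronger inhibitor of growth.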